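Amino for nitro in a series held at limit

The source may report more compounds than this note shows. Statements on the series, on what has been measured and on what is new or still open speak of the compounds shown alone.

Values in a functional assay on HT-29 cells (Homo sapiens) for cytotoxicity, read by MTT assay, with a stated time of 6 days; on this read-out higher numbers stand for an effect only at larger amounts of compound and lower numbers for an effect already at smaller amounts (all three are limits):
compound 1 `COC(=O)c1c(-c2ccc(OC)cc2)oc2ccccc2c1=O` > 25 ug/mL
compound 2 `COC(=O)c1c(-c2ccc(Br)cc2)oc2ccccc2c1=O` > 25 ug/mL
compound 3 `COC(=O)c1c(-c2ccc([N+](=O)[O-])cc2)oc2ccccc2c1=O` > 25 ug/mL

Compound 3 gives only the limit > 25 ug/mL and not a number. The series as a whole offers only the limit of > 25 ug/mL in this assay, at which 3 of the 3 values shown sit, and so its members cannot be ranked. Compound 4 `COC(=O)c1c(-c2ccc(N)cc2)oc2ccccc2c1=O` carries amino in place of nitro, on an aromatic carbon para to a large group (amino in place of nitro on an aromatic carbon) with the rest unchanged. The bearing steps are a step that the two limits leave unreadable from compound 1 to compound 3 and a step that the two limits leave unreadable from compound 2 to compound 3 and a step that the two limits leave unreadable from compound 1 to compound 2 and none of them gives a size. No direction or size is therefore expected from them, and the expected move is only a number no higher from compound 3 to compound 4 (the limit leaves the size open) as a rough estimate. In this assay the estimate for compound 4 is 25 ug/mL with an expected range from 8 ug/mL to 50 ug/mL and another limit is quite likely.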

Compound 4, concentration for half-maximal effect: > 25 ug/mL
Compound 4 was reported as a limit; the forecaster's own chance of this, stated with the estimate: 70%; the middle value lies on the limit itself.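

No step from compound 1, compound 2 or compound 3 to compound 4 can be read, as all four compounds sit at one limit: the limit of > 25 ug/mL in this assay, at which 4 of the 4 values shown sit.

As far as these compounds go, how methoxy, bromo, nitro and amino rank against one another remains open.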